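A few compounds are considered here, and "the series" means these few. Any claim that something is new, unique, unknown or untested is made for them only; others in the source may bear on it.

Measured compounds in a functional assay on LoVo cells (Homo sapiens) for inhibition, read by colorimetric assay and MTT assay, with a stated time of 72 h; on this read-out higher numbers stand for weaker inhibition and lower numbers for stronger inhibition:

compound 1, `C=CCCCCOc1ccccc1-c1cnc(OCCC=C)n1C`: 12000 nM
compound 2, `C=CCCCCOc1ccccc1-c1cnc(OCCCCC=C)n1C`: 5000 nM
compound 3, `C=CCCOc1ncc(-c2ccccc2OC)n1C`: 24000 nM

Compounds 1 and 2 share one core, compound 3 another. The two cores differ as given by hydrogen in place of pent-4-en-1-yl on a saturated chain carbon bound to an oxygen on an aromatic ring; in this assay that change gave a 2.0-fold higher number from compound 1 to compound 3 (0.30 log units; within the scatter), so compound 1 and compound 3 cannot be told apart on this read-out. Compound 3 and compound 2 are further apart, as their two values show.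

Within the first core, the change but-3-en-1-yl in place of vinyl on a saturated chain carbon, two bonds along the chain from an oxygen on an aromatic ring has been measured once and gave a 2.4-fold lower number from compound 1 to compound 2 (0.38 log units; beyond the scatter), a modest but real lowering of the number.

Compound 4, `C=CCCCCOc1ncc(-c2ccccc2OC)n1C`, is to be measured in this assay. It arises from compound 3 by but-3-en-1-yl in place of vinyl on a saturated chain carbon, two bonds along the chain from an oxygen on an aromatic ring. The place of this change is the same, word for word, as in the step from compound 1 to compound 2, so it is the same change carried onto the second core.

The expectation for compound 4 rests on a single prior instance of the change; whether it transfers across the difference in core is not known from these three compounds. The step is expected to be about a 2.0-fold lower number from compound 3 to compound 4 (0.30 log units; within the scatter), a little more cautious than the step seen from compound 1 to compound 2 because that step, a 2.4-fold lower number from compound 1 to compound 2 (0.38 log units; beyond the scatter), was only modest. Compound 4 is therefore estimated at 12000 nM, with a likely range from 5500 nM to 26000 nM.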

Compound 4, half-maximal inhibitory concentration: 4000 nM
Compound 4: middle estimate off by 3.0-fold (0.48 log units), on the high side; the whole stated range lies above it.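

In this assay, replacing the (but-3-en-1-yl)oxy group with (hex-5-en-1-yl)oxy on the core of compound 3 gave a 6.0-fold lower number from compound 3 to compound 4 (0.78 log units; beyond the scatter), the same direction as on the core of compound 1, and the two steps cannot be told apart in size: the same change on two cores in this assay, a 2.4-fold lower number (0.38 log units; beyond the scatter) from compound 1 to compound 2 and a 6.0-fold lower number (0.78 log units; beyond the scatter) from compound 3 to compound 4, 2.5-fold (0.40 log units) apart, within the scatter of two such steps

The core difference, measured with the longer chain in place, gave a 1.3-fold lower number from compound 2 to compound 4 (0.10 log units; within the scatter), so compound 2 and compound 4 cannot be told apart on this read-out, and this step also agrees with its earlier counterpart: the same change on two cores in this assay, a 2.0-fold higher number (0.30 log units; within the scatter) from compound 1 to compound 3 and a 1.3-fold lower number (0.10 log units; within the scatter) from compound 2 to compound 4, 2.5-fold (0.40 log units) apart, within the scatter of two such steps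

This is one pair of steps on two cores: it supports carrying the chain change from one of these cores to the other, but it does not establish a fixed size for the step or show that the change would hold on any further core.

Still open, on these data alone, is whether a saturated hexyl chain would match hex-5-en-1-yl, and whether a longer chain, or a chain ending in an amine or a carboxylic acid, would lower the number further on either core. Also open, as far as these compounds go, is whether these steps would hold in a cell line other than the one used here.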